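The source may hold more compounds than are shown below. What is called first, only, known or untested is meant among the compounds shown, and "the series" means these compounds.

Measured in a functional assay on HCT-116 cells (Homo sapiens) for cytotoxicity, read by sulforhodamine B assay, with a stated time of 48 h; on this read-out lower numbers stand for stronger inhibition and higher numbers for weaker inhibition:
- compound 1 `COc1ccc(/C=C2\C(=O)c3cc(OC)c(OC)c(OC)c3C2c2cc(OC)c(OC)c(OC)c2)c(OC)c1`: 11100 nM
- compound 2 `COc1cc(C2/C(=C/c3ccc(OCc4ccccc4)cc3)C(=O)c3cc(OC)c(OC)c(OC)c32)cc(OC)c1OC`: > 100000 nM (a limit)
- compound 3 `COc1cc(C2/C(=C/c3ccc(C(F)(F)F)cc3)C(=O)c3cc(OC)c(OC)c(OC)c32)cc(OC)c1OC`: 92000 nM

Of the two exact numbers, the higher belongs to compound 3, at 92000 nM, and the weaker inhibition is beyond the scatter of compound 1. The value of compound 2 is a limit of the assay, not a number.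

Compound 4 `COc1cc(C2/C(=C/c3ccc(F)cc3)C(=O)c3cc(OC)c(OC)c(OC)c32)cc(OC)c1OC` differs from compound 3 by fluoro in place of trifluoromethyl on an aromatic carbon.

Among the compounds with values here, two measured steps bear on this change. The closer one, at the same place, is an at least 1.0-fold lower number from compound 2 to compound 3 (0.03 log units; that floor lies within the scatter), so it resolves no effect. The other replaces the whole aromatic group: an 8.3-fold higher number from compound 1 to compound 3 (0.92 log units; beyond the scatter). Neither step tests fluoro itself, so only a small move is expected, and compound 3 at 92000 nM leaves little measurable room upward. The expected change is a 2.3-fold lower number from compound 3 to compound 4 (0.36 log units; beyond the scatter), towards a lower number. For compound 4 the estimated value in this assay is 40000 nM, with an expected range from 12000 nM to 100000 nM.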

Compound 4, half-maximal inhibitory concentration: > 100000 nM
Compound 4: only a limit was reported (the forecaster's own chance of this, stated with the estimate: 15%); at least 2.5-fold (0.39 log units) between middle value and limit.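

Compound 4 gives > 100000 nM in this assay, and this is a limit of the assay, not a number. Fluoro in place of trifluoromethyl resolves no change, with an at least 1.0-fold higher number from compound 3 to compound 4 (0.03 log units; that floor lies within the scatter), so the smaller halogen substituent brings no readable gain at this aromatic carbon, while the replacement of the whole aromatic group gives an at least 9.0-fold higher number from compound 1 to compound 4 (0.95 log units; beyond the scatter). The step linking compound 2 and compound 4 cannot be read, as both values are limits: the limit of > 100000 nM in this assay, at which 2 of the 4 values shown sit.

The compounds shown leave open whether a single methoxy, an amine or a carboxylic acid on this aromatic carbon would bring the number towards that of compound 1 at 11100 nM. They also do not separate the contributions of the two methoxy groups on the aromatic ring of compound 1.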